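A few compounds are considered here, and "the series" means these few. Any claim that something is new, unique, unknown or untested is made for them only; others in the source may bear on it.

Measured compounds:
- Compound 1 `O=C(Nc1cccc(S(=O)(=O)C2CCCC2)n1)c1ccc(NCCO)cc1N1CCC2(CC1)CC2`: in an ADME assay on microsomes from liver (Mus musculus) for metabolic stability, read by LC-MS, with a stated time of 40 min, tested at 0.5 uM (a higher number here means faster removal of the compound, a lower number slower removal), compound 1 gives > 399 mL.min-1.g-1, which is a limit of the assay rather than a number.
- Compound 2 `O=C(Nc1cccc(S(=O)(=O)N2CCCC2)c1)c1cccnc1N1CCC2(CC1)CC2`: in this assay compound 2 gives > 399 mL.min-1.g-1, again a limit of the assay.
- Compound 3 `O=C(Nc1cccc(S(=O)(=O)C2CCCC2)c1)c1cccnc1N1CCCCC1`: in this assay compound 3 gives > 399 mL.min-1.g-1, also a limit of the assay.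

Compound 2 therefore stands at the limit of this assay, not at a measured number, and the same is true of the other two compounds, because of the limit of > 399 mL.min-1.g-1 in this assay, at which 3 of the 3 values shown sit. None of these compounds differs from another in a single place, so no step between measured compounds can be read from them.

Compound 4 `O=C(Nc1cccc(S(=O)(=O)C2COC2)c1)c1cccnc1N1CCC2(CC1)CC2` is the next compound to be measured in this assay. It is built from compound 2 by a single change: oxetan-3-yl in place of pyrrolidin-1-yl on a sulfonyl sulfur. The change swaps a five-membered non-aromatic ring with one nitrogen for a four-membered non-aromatic ring with one oxygen, on a sulfonyl sulfur whose other neighbour is an aromatic carbon.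

With all three measured compounds sitting at the limit, no direction for this kind of change can be drawn from the shown numbers. The step from compound 2 to compound 4 is expected to be an at least 1.2-fold lower number from compound 2 to compound 4 (0.09 log units; that floor lies within the scatter), that is, no more than the usual scatter. For compound 4 the estimate in this assay is 320 mL.min-1.g-1, with a range from 110 mL.min-1.g-1 to 600 mL.min-1.g-1.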

Compound 4, intrinsic clearance in microsomes: 385 mL.min-1.g-1
The estimate for compound 4 lay 1.2-fold (0.08 log units) below the measured number, within the range that was stated.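

Among the compounds shown, compound 4 is the only one with a real number in this assay, and that number, 385 mL.min-1.g-1, still means very fast removal. Putting oxetan-3-yl in place of pyrrolidin-1-yl on a sulfonyl sulfur gives an at least 1.0-fold lower number from compound 2 to compound 4 (0.01 log units; that floor lies within the scatter), so this change shows no clear slowing of removal. That floor is all that can be read, and the full size of the step stays unknown, because compound 2 stands at a limit and not at a number: the limit of > 399 mL.min-1.g-1 in this assay, at which 3 of the 4 values shown sit.

As far as these compounds go, whether another group on the sulfonyl sulfur, such as methyl or a dimethylamino group, would bring the number clearly down remains open. Also open, from the compounds shown here alone, is whether oxetan-3-yl would behave the same way on the core of compound 1.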